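Cytotoxicity notes: ethyl in place of allyloxy

The source may report more compounds than this note shows. Statements on the series, on what has been measured and on what is new or still open speak of the compounds shown alone.

Measured so far:
compound 1 `O=C(Nc1cccc(Oc2nccc(C(F)(F)F)c2Cl)c1)C1CCCN(C(=O)c2cc(C(F)(F)F)cc(C(F)(F)F)c2)C1` — 0%
compound 2 `COC(=O)c1cccc(NC(=O)C2CCCN(C(=O)c3cc(C(F)(F)F)cc(C(F)(F)F)c3)C2)c1` — 0%
compound 3 `C=CCOc1cccc(NC(=O)C2CCCN(C(=O)c3cc(C(F)(F)F)cc(C(F)(F)F)c3)C2)c1` — 0%

All three compounds share one core and differ only in the group on the aromatic carbon of the anilide-side ring. In an ADME assay on PC-3 cells (Homo sapiens) for cytotoxicity, read by WST assay, tested at 100 uM (a higher number here means more inhibition at the concentration tested (going by the name of the read-out), a lower number less inhibition), compound 3 gives 0%, level with compound 1 and compound 2 at the digits shown. The steps within the set are flat: no change at the digits printed from compound 1 to compound 2 (within the scatter), no change at the digits printed from compound 1 to compound 3 (within the scatter) and no change at the digits printed from compound 2 to compound 3 (within the scatter), each within the scatter, although the groups exchanged range from a (3-chloro-4-(trifluoromethyl)pyridin-2-yl)oxy to a methoxycarbonyl to an allyloxy.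

Compound 4 `CCc1cccc(NC(=O)C2CCCN(C(=O)c3cc(C(F)(F)F)cc(C(F)(F)F)c3)C2)c1` is not yet measured. Its change from compound 3 is ethyl in place of allyloxy on an aromatic carbon.

Within the data shown here, no step among the measured compounds exchanges exactly this pair of groups, so the three flat steps are the only guide. Those steps show that larger changes at this same aromatic carbon left this assay unchanged, so the step to compound 4 is expected to stay within the scatter as well: no change at the digits printed from compound 3 to compound 4 (within the scatter). Compound 4 is therefore expected to give about 0% in this assay, within a range from 0% to 10%.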

Compound 4, a percentage reported as inhibition, at one concentration (the size of the read-out at that concentration, not a potency): 0%
Estimate against measurement, compound 4: no gap at the digits printed; measured number inside the range.
By their numbers in this assay, from the lowest: compounds 1, 2, 3 and 4 (each within the scatter of the next).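

Among these compounds, compound 4 carries ethyl on this aromatic carbon, the first group in the set with no oxygen and no hydrogen-bond acceptor, and this assay still does not separate it from the others: the reading shows no change at the digits printed from compound 3 to compound 4 (within the scatter), no change at the digits printed from compound 2 to compound 4 (within the scatter) and no change at the digits printed from compound 1 to compound 4 (within the scatter). The number in this assay is therefore level, at this single concentration, with a small all-carbon alkyl group on this position as with the allyloxy, the methoxycarbonyl and the much larger (3-chloro-4-(trifluoromethyl)pyridin-2-yl)oxy, so neither the oxygen of the allyloxy nor its double bond is needed for the flat reading. No measured property of these compounds bears on why the reading stays flat.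

With all four compounds at one reading, the set gives no ranking of groups and cannot show which change at this aromatic carbon, if any, would raise the inhibition. Going by these compounds, whether an amine, a carboxylic acid or a longer chain on this carbon would read the same stays open, as does the effect of any change elsewhere on the shared core.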